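The compounds below may be only part of what the source reports. "The series", "measured", "known", "first", "only" and "open" are said of these compounds alone.

Three compounds have so far been measured in a physicochemical assay for solubility, read by nephelometry, in phosphate buffer, measured as kinetic solubility, at pH 6.5 (on this read-out higher numbers stand for higher solubility and lower numbers for lower solubility), and gave these values:

Compound 1 `O=C(NNS(=O)(=O)c1ccccc1F)c1cc(F)cc(-n2cccn2)c1` gives 25 ug/mL
Compound 2 `Cc1cc(-c2ncccn2)cc(C(=O)NNS(=O)(=O)c2ccccc2)c1F` gives 50 ug/mL
Compound 3 `CC(C)Oc1cccc(C(=O)NNS(=O)(=O)c2ccccc2F)c1` gives 50 ug/mL

Compound 2 stands level with compound 3 at the digits reported, and its gap to compound 1 lies within the usual scatter, so the three cannot be ranked. Compound 4 `Cc1cc(-c2ccccn2)cc(C(=O)NNS(=O)(=O)c2ccccc2)c1F` departs from compound 2 in one place, with pyridin-2-yl in place of pyrimidin-2-yl on an aromatic carbon, para to a fluoro group and meta to a methyl group (pyridin-2-yl in place of pyrimidin-2-yl on an aromatic carbon). Within the data shown here, no pair of measured compounds differs in one place only, so no measured step is available as a guide. In this assay no step beyond the scatter is expected, and the forecast therefore stays close to compound 2 at 50 ug/mL in this series. The expected outcome is a 1.3-fold lower number from compound 2 to compound 4 (0.10 log units; within the scatter) and this estimated step remains within the scatter. For compound 4 the estimated value is 40 ug/mL with an expected range from 18 ug/mL to 80 ug/mL in this measurement.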

Compound 4, solubility: 6.3 ug/mL
Compound 4: middle estimate off by 6.3-fold (0.80 log units), on the high side, outside the stated range (below it).
By their numbers in this assay, from the lowest: compound 4; then compounds 1, 2 and 3 (each within the scatter of the next).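

In this assay, among these compounds, putting pyridin-2-yl in place of pyrimidin-2-yl on this aromatic carbon, para to a fluoro group and meta to a methyl group, gives a 7.9-fold lower number from compound 2 to compound 4 (0.90 log units; beyond the scatter), the first measured step that stands clear of the scatter. The read-out at this position therefore depends strongly on the ring placed there, even though both rings have 6 heavy atoms and no net charge and differ in having 2 hetero atoms or 1. Nothing available accounts for the size of this step.

The compounds shown leave open how an amine or a carboxylic acid on this same aromatic carbon would read in this assay. They also leave open whether the same ring exchange would give a step of similar size on another core.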